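Methyl on the aromatic nitrogen of compound 1

This account rests on a few compounds, and the source may have more. Where it says the series, first, only, none or still open, it means among the compounds named here.

Compound 1 `COc1cc(C(=O)NS(=O)(=O)c2ccccc2)ccc1Cc1c[nH]c2ccc(NC(=O)OC3CCCC3)cc12` is the reference of this set. In an assay on isolated protein (Cavia porcellus) with cysteinyl leukotriene receptor (Homo sapiens) as the target (a higher number here means a more potent compound, by a factor of ten per unit of this negative logarithm, a lower number a less potent compound), compound 1 gives 9.8, level at the digits shown with compound 3 `COc1cc(C(=O)NS(=O)(=O)c2ccccc2)ccc1Cc1cn(C)c2ccc(NC(=O)CC3CCCC3)cc12`, which in this assay gives 9.8; these two are together the highest of the three numbers, and the gap between them lies within the scatter. Compound 2 `COc1cc(C(=O)O)ccc1Cn1ccc2ccc(NC(=O)OC3CCCC3)cc21` stands furthest away, with 7.8 in this assay, a number well below compound 1 and beyond the scatter. Among the measured compounds shown here, no single-change step between measured compounds is available, so the pairs can only be read by their values.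

Compound 4 `COc1cc(C(=O)NS(=O)(=O)c2ccccc2)ccc1Cc1cn(C)c2ccc(NC(=O)OC3CCCC3)cc12` is not yet measured. It differs from compound 1 in one place, (methyl in place of hydrogen on an aromatic nitrogen). Compound 3 carries the same methyl on the aromatic nitrogen and gives 9.8, so the methyl appears compatible with a high number. The step of no change at the digits printed from compound 1 to compound 4 (within the scatter) is expected to be none beyond the scatter. For compound 4 the estimate in this assay is 9.8, with a range from 9.3 to 10.3.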

Compound 4, negative logarithm of the antagonist equilibrium constant: 9.69
Compound 4: the middle estimate sits 0.11 log units above what was measured; the range from low to high includes it.
By their numbers in this assay, from the lowest: compound 2; then compounds 4, 1 and 3 (each within the scatter of the next).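

In this assay, methyl in place of hydrogen on an aromatic nitrogen reads as a number 0.11 log units lower from compound 1 to compound 4 (within the scatter), so hydrogen and methyl at this position cannot be told apart with cyclopentyloxy on the carbonyl carbon. With methyl held on that nitrogen, cyclopentyloxy in place of cyclopentylmethyl on a carbonyl carbon reads as a number 0.11 log units lower from compound 3 to compound 4 (within the scatter), and these two groups cannot be told apart either. No measured property bears on either step, so neither can be explained from the data at hand.

Open, as far as these compounds go, is whether an ethyl group, or a longer chain ending in an amine, on this nitrogen would keep the number at this level. Also open is whether hydrogen and methyl stay equivalent with cyclopentylmethyl on the carbonyl carbon, since compound 3 has no partner bearing hydrogen on that nitrogen among the compounds shown.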